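Trading the azepane of compound 3 for a hydroxypiperidine

The compounds below may be only part of what the source reports. "The series", "measured", "known", "first", "only" and "open" are said of these compounds alone.

Three compounds share one core and differ only in the saturated amine attached to the piperidine carbon. Compound 3 `Cc1cc(C)c(S(=O)(=O)N2CCC(N3CCCCCC3)CC2)c(C)c1` gives the lowest number of the three in a functional assay on DLD-1 cells (Homo sapiens) for antiproliferative activity, read by CellTiter-Glo, with a stated time of 72 h (on this read-out lower numbers stand for stronger inhibition and higher numbers for weaker inhibition), namely 5.3 nM. Compound 1 `Cc1cc(C)c(S(=O)(=O)N2CCC(N3CCC(CCO)CC3)CC2)c(C)c1` gives 19 nM in this assay, and compound 2 `Cc1cc(C)c(S(=O)(=O)N2CCC(N3CCN(C)CC3)CC2)c(C)c1` gives 1100 nM. Accordingly the change a 3.6-fold lower number from compound 1 to compound 3 (0.55 log units; beyond the scatter), while the change a 210-fold lower number from compound 2 to compound 3 (2.32 log units; beyond the scatter).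

Compound 4 `Cc1cc(C)c(S(=O)(=O)N2CCC(N3CCC(O)CC3)CC2)c(C)c1` has not yet been measured. It differs from compound 3 in that (4-hydroxypiperidin-1-yl in place of azepan-1-yl on a saturated ring carbon). For the measured compounds named here, two measured steps bear on this change. The step from compound 1 to compound 3 also replaced a piperidine carrying a hydroxyl-bearing chain with the azepane, and it was modest; the step from compound 2 to compound 3 replaced a piperazine and was large. The new group in compound 4 resembles that of compound 1 more closely than that of compound 2, so the return from azepane to a hydroxyl-bearing piperidine is expected to cost roughly what the change from compound 1 to compound 3 gained, perhaps somewhat more. For compound 4 in this assay the expected step is a 5.7-fold higher number from compound 3 to compound 4 (0.75 log units; beyond the scatter), and the estimated value is 30 nM with a range from 8 nM to 120 nM.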

Compound 4, half-maximal inhibitory concentration: 106 nM
Estimate against measurement, compound 4: 3.5-fold (0.55 log units) below; the measured number falls inside the stated range.
By their numbers in this assay, from the lowest: compound 3; then compound 1; then compound 4; then compound 2.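

In this assay the swap gives a 20-fold higher number from compound 3 to compound 4 (1.30 log units; beyond the scatter), a larger change than the earlier step between compound 1 and compound 3 implied, even though azepan-1-yl and 4-hydroxypiperidin-1-yl have the same count of heavy atoms. A hydroxyl-bearing piperidine does not by itself set the level at this position: hydroxy in place of 2-hydroxyethyl gives a 5.6-fold higher number from compound 1 to compound 4 (0.75 log units; beyond the scatter), although both compounds keep a hydroxyl on the piperidine ring. Compound 4 still remains clearly ahead of the methylpiperazine, with a 10-fold lower number from compound 2 to compound 4 (1.02 log units; beyond the scatter), so the four amines now fall in the order compound 3, compound 1, compound 4, compound 2, each separated from the next by more than the scatter.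

On these data alone, it remains open whether the length of the chain or the hydroxyl itself accounts for the gap between compound 1 and compound 4, a question that an unsubstituted piperidine, a 4-methoxypiperidine or a longer 3-hydroxypropyl chain would bear on. Nothing measured here gives a reason for any of these steps.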